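Swapping dimethylamino for 4-(methoxycarbonyl)piperidin-1-yl

The compounds below may be only part of what the source reports. "The series", "measured", "known", "first", "only" and "open" are said of these compounds alone.

Compound 1 `Cc1ccc(-c2nc3ccccc3s2)cc1NC(=O)c1cc([N+](=O)[O-])c(N2CCC(C(=O)O)CC2)cc1Cl`: > 25000 nM, a limit
Compound 2 `Cc1ccc(-c2nc3ccccc3s2)cc1NC(=O)c1cc([N+](=O)[O-])c(N(C)C)cc1Cl`: > 25000 nM, a limit

In an ADME assay on HEK293 cells (Homo sapiens) for cytotoxicity, with a stated time of 72 h (on this read-out lower numbers stand for an effect already at smaller amounts and higher numbers for an effect only at larger amounts of compound), compound 2 stands at > 25000 nM, which is a limit and not a number. Compound 3 `COC(=O)C1CCN(c2cc(Cl)c(C(=O)Nc3cc(-c4nc5ccccc5s4)ccc3C)cc2[N+](=O)[O-])CC1` differs from it in one place: 4-(methoxycarbonyl)piperidin-1-yl in place of dimethylamino on an aromatic carbon. There, 4-(methoxycarbonyl)piperidin-1-yl takes the place of dimethylamino on an aromatic carbon, ortho to a nitro group.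

Among the compounds with values here, only one measured step bears on this change: a step that the two limits leave unreadable from compound 1 to compound 2. It concerns the same place, but it offers no size to carry over. Its two ends are the limit of > 25000 nM in this assay, at which 2 of the 2 values shown sit. Compound 1, with 4-carboxypiperidin-1-yl there, reads > 25000 nM, also a limit. No step beyond the scatter is therefore expected in this assay, and another limit is the likeliest result. The expected step is a number no higher from compound 2 to compound 3 (the limit leaves the size open). For compound 3 the estimate is 25000 nM, with an expected range from 12000 nM to 50000 nM.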

Compound 3, half-maximal effective concentration: > 25000 nM
Compound 3: only a limit was reported; the forecaster's own chance of this, stated with the estimate: 75%; the middle value lies on the limit itself.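

No step can be read among compound 1, compound 2 and compound 3, because all three sit at the same limit: the limit of > 25000 nM in this assay, at which 3 of the 3 values shown sit.

As far as these compounds go, what stays open is how far apart the three compounds lie, and whether the group at this place affects the read-out at all.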